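Changing the Butoxy Group on a Weak Inhibitor

The compounds below may be only part of what the source reports. "The series", "measured", "known", "first", "only" and "open" are said of these compounds alone.

In a functional assay on brain (Rattus norvegicus, strain Wistar) for inhibition (a higher number here means a weaker inhibitor, a lower number a stronger inhibitor), compound 2 (`CCCCOc1ccc(-c2c(C)[nH]c(=O)n2C2CCCCC2)cc1`) gives 13900 nM as its result. Compound 1 (`CCCCOc1ccc(-c2c(C)[nH]c(=O)n2C)cc1`) gives 5100 nM as its result, and the measured comparison shows a 2.7-fold higher number from compound 1 to compound 2 (0.44 log units; beyond the scatter) for this pair. Compound 3 (`CCCCCCCCCCOc1ccc(-c2c(C)[nH]c(=O)n2C)cc1`) gives 6900 nM as its result, within the usual scatter of compound 2.

Compound 4 (`Cc1[nH]c(=O)n(C2CCCCC2)c1-c1ccc(CC(C)C)cc1`) keeps the cyclohexyl of compound 2 but has isobutyl in place of butoxy on an aromatic carbon, a change counted as isobutyl in place of butoxy on an aromatic carbon here. For the measured compounds named here, no measured pair makes this exact swap. The nearest guide is a change to the butoxy chain itself: hexyl in place of hydrogen on a saturated chain carbon gave a 1.4-fold higher number from compound 1 to compound 3 (0.13 log units; within the scatter) in that comparison. The cyclohexyl step does not bear on the swap, since compound 2 and compound 4 share that group. No shift beyond the scatter is therefore expected in this assay for this swap. The expected change is a 1.2-fold lower number from compound 2 to compound 4 (0.06 log units; within the scatter) by this estimate. For compound 4 the estimated value is 12000 nM with an expected range from 4000 nM to 35000 nM in this test.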

Compound 4, half-maximal inhibitory concentration: 10900 nM
Estimate against measurement, compound 4: 1.1-fold (0.04 log units) above, within the range that was stated.
By their numbers in this assay, from the lowest: compounds 1, 3, 4 and 2 (each within the scatter of the next, the first and the last beyond it).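

In this assay, replacing butoxy with isobutyl gives a 1.3-fold lower number from compound 2 to compound 4 (0.11 log units; within the scatter), so the swap produces no shift beyond the scatter. The earlier compounds shown here changed only the length of the chain and always kept the oxygen on the aromatic ring, whereas this change removes that oxygen, along with its one hydrogen-bond acceptor, and puts a different carbon chain in its place. With cyclohexyl on the nitrogen, then, the result at this position does not depend on that oxygen being present. Nothing available explains why the number holds. On these data alone, it remains open whether isobutyl would behave the same way with methyl on the nitrogen, as in compound 1. Also open, as far as these compounds go, is whether an amine or a carboxylic acid at this position would move the number beyond the scatter.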